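Estimating Compound 4 from Three Measured Analogues

The source may report more compounds than this note shows. Statements on the series, on what has been measured and on what is new or still open speak of the compounds shown alone.

Three measured compounds share one core and differ only in the aryl group carried on the aromatic nitrogen. In a functional assay on HepG2 cells (Homo sapiens) for inhibition, read by MTT assay, with a stated time of 72 h (on this read-out higher numbers stand for weaker inhibition and lower numbers for stronger inhibition), compound 1 `CCc1ccccc1-n1cc(COc2cccc(NC(=O)Nc3ccc(Cl)c(C(F)(F)F)c3)c2)nn1` gives 3530 nM. Compound 2 `O=C(Nc1cccc(OCc2cn(-c3cccc(Cl)c3)nn2)c1)Nc1ccc(Cl)c(C(F)(F)F)c1` gives 2020 nM, and compound 3 `O=C(Nc1cccc(OCc2cn(-c3ccccc3Br)nn2)c1)Nc1ccc(Cl)c(C(F)(F)F)c1` gives 2810 nM. On these numbers compound 3 stands second highest, with compound 1 nearest and compound 2 furthest; both gaps, a 1.3-fold lower number from compound 1 to compound 3 (0.10 log units; within the scatter) and a 1.4-fold higher number from compound 2 to compound 3 (0.14 log units; within the scatter), lie within the scatter of this assay.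

Compound 4 `O=C(Nc1cccc(OCc2cn(-c3cccc(I)c3)nn2)c1)Nc1ccc(Cl)c(C(F)(F)F)c1` is reached from compound 3 by 3-iodophenyl in place of 2-bromophenyl on an aromatic nitrogen. Going by the values given here, two measured steps bear on this kind of exchange of one halogenated aryl group for another on the aromatic nitrogen: a 1.4-fold higher number from compound 2 to compound 3 (0.14 log units; within the scatter) and, from a 2-ethylphenyl to a 3-chlorophenyl, a 1.7-fold lower number from compound 1 to compound 2 (0.24 log units; within the scatter). Neither moved the number beyond the scatter, and the data hold no halogen-for-halogen exchange at all. Compound 4 is therefore expected to show no step beyond the scatter, a 1.1-fold lower number from compound 3 to compound 4 (0.05 log units; within the scatter). The value of compound 4 is estimated at 2500 nM, with an expected range from 1200 nM to 5200 nM.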

Compound 4, half-maximal inhibitory concentration: 4780 nM
Compound 4: the middle estimate sits 1.9-fold (0.28 log units) below what was measured, within the range that was stated.
By their numbers in this assay, from the lowest: compounds 2, 3, 1 and 4 (each within the scatter of the next, the first and the last beyond it).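

In this assay the exchange of chloro for iodo on the aryl group carried by the aromatic nitrogen, with the substituent numbered 3 in both groups, gives a 2.4-fold higher number from compound 2 to compound 4 (0.37 log units; beyond the scatter), the only step among these four compounds that passes beyond the scatter, and a modest one. The other two new steps, a 1.7-fold higher number from compound 3 to compound 4 (0.23 log units; within the scatter) and a 1.4-fold higher number from compound 1 to compound 4 (0.13 log units; within the scatter), stay within the scatter, so compound 1, compound 3 and compound 4 cannot be put in order, and only compound 2 and compound 4 are told apart by this read-out. The halogen on this aryl group can therefore shift the number, although that rests on a single pair, and nothing at hand offers an explanation for the shift.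

As far as these compounds go, what stays open is whether a 3-bromophenyl or a 3-fluorophenyl group would fall with the 3-chlorophenyl of compound 2 or with the 3-iodophenyl of compound 4. It is also open whether a 3-aminophenyl or a 3-carboxyphenyl group on the same nitrogen would move the number further than any halogen shown here.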